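Little Antiproliferative Signal Across the Benzylamino Series

This account rests on a few compounds, and the source may have more. Where it says the series, first, only, none or still open, it means among the compounds named here.

Measured so far in a functional assay on MCF cells (Homo sapiens) for antiproliferative activity, with a stated time of 72 h; a lower number here means a stronger inhibitor, a higher number a weaker inhibitor:
- Compound 1 `OC[C@H]1O[C@@H](n2cnc3c(NCc4ccc(Cl)cc4)ncnc32)[C@H](O)[C@@H]1O`: > 166000 nM (a limit)
- Compound 2 `OC[C@H]1O[C@@H](n2cnc3c(NCc4ccccc4Br)ncnc32)[C@H](O)[C@@H]1O`: > 166000 nM (a limit)
- Compound 3 `OC[C@H]1O[C@@H](n2cnc3c(NCc4ccc(Cl)c(Cl)c4)ncnc32)[C@H](O)[C@@H]1O`: 88800 nM

Among the measured compounds shown here, compound 3 holds the only true number, 88800 nM, in this assay so far. Compound 1 and compound 2 both rest on (the limit of > 166000 nM in this assay, at which 2 of the 3 values shown sit), which is a limit and not a number.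

The next compound, compound 4 `OC[C@H]1O[C@@H](n2cnc3c(NCc4c(F)ccc(F)c4F)ncnc32)[C@H](O)[C@@H]1O`, carries 2,3,6-trifluorophenyl in place of 3,4-dichlorophenyl on a saturated chain carbon bound to a nitrogen on an aromatic ring. Three measured steps change this same part of the molecule. Two of them end at compound 3, namely an at least 1.8-fold lower number from compound 1 to compound 3 (0.27 log units; that floor lies within the scatter) and an at least 1.8-fold lower number from compound 2 to compound 3 (0.27 log units; that floor lies within the scatter). The third, a step that the two limits leave unreadable from compound 1 to compound 2, gives no size. None of them brings in fluorine, so the guidance is thin.

In this assay, for the measured compounds named here, no step clearly beyond the scatter is expected, and any drift is expected toward a higher number. The expected move is a 1.5-fold higher number from compound 3 to compound 4 (0.17 log units; within the scatter) as an estimate. For compound 4 the estimated value is 130000 nM, with an expected range of 60000 nM to 280000 nM.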

Compound 4, half-maximal inhibitory concentration: > 166000 nM
Compound 4: no number, only a limit; the forecaster's own chance of this, stated with the estimate: 55%; at least 1.2-fold (0.10 log units) between middle value and limit.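

In this assay, among the compounds shown here, the swap to 2,3,6-trifluorophenyl puts fluorine at this place, where the earlier compounds carry only chlorine or bromine, and it gives an at least 1.8-fold higher number from compound 3 to compound 4 (0.27 log units; that floor lies within the scatter). Compound 4 thus does not keep a true number, although that floor does not show a real loss. Compound 4 rests on a limit, the same one that holds for most of the series: the limit of > 166000 nM in this assay, at which 3 of the 4 values shown sit.

The steps to compound 4 from compound 1 and from compound 2 join two limits and cannot be read.

For the compounds shown here, compound 3 therefore remains the only compound here with a true number, and it is unclear whether any group at this place can give a clearly lower one. From the compounds shown here alone, how a methoxy group or a carboxylic acid on this aromatic ring would read stays open, as does a longer chain on the nitrogen.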